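The source may hold more compounds than are shown below. What is called first, only, known or untested is meant among the compounds shown, and "the series" means these compounds.

Measured so far in an ADME assay on SH-SY5Y cells (Homo sapiens) for cytotoxicity, read by MTT assay, with a stated time of 48 h; on this read-out higher numbers stand for weaker inhibition and lower numbers for stronger inhibition:
- compound 1 `COc1ccc(C(=O)/C=C/c2ccc(C(=O)N3CCCC3)cc2)c(O)c1`: > 100000 nM
- compound 2 `COc1ccc(C(=O)/C=C/c2cc(OC)c(OC)c(OC)c2)c(O)c1`: > 100000 nM
- compound 3 `COc1ccc(C(=O)/C=C/c2cc(OC)c(OC)cc2OC)c(O)c1`: > 100000 nM

Going by the values given here, each of these entries is a limit of the assay and not a number, and the series so far sits entirely at the limit of > 100000 nM in this assay, at which 3 of the 3 values shown sit. Among the compounds with values here, no compound can therefore be ranked against another. Compound 1 stands with > 100000 nM, which is a limit.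

Compound 4 `COc1ccc(C(=O)/C=C/c2ccc(C(=O)Nc3ccccc3O)cc2)c(O)c1` keeps the core of compound 1 and carries (2-hydroxyphenyl)amino in place of pyrrolidin-1-yl on a carbonyl carbon. The change brings in a six-membered aromatic ring of carbon only. Within the data shown here, no measured pair in this assay differs in one place, so the data offer no step size for this change.

The expected step is a number no higher from compound 1 to compound 4 (the limit leaves the size open), which means none beyond the scatter, although any departure would be expected toward stronger inhibition. Another limit rather than a number would be no surprise. For compound 4 the estimate is 100000 nM, with an expected range from 30000 nM to 300000 nM.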

Compound 4, half-maximal inhibitory concentration: > 100000 nM
Compound 4 was reported as a limit; the forecaster's own chance of this, stated with the estimate: 70%; the middle value sits exactly at the limit.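

The results for compound 1 and compound 4 in this assay are both limits and not numbers, so no step can be read between them. The compounds shown leave open whether any change to the shared core gives a measurable value: the limit of > 100000 nM in this assay, at which 4 of the 4 values shown sit.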